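Fluorosulfonyl series: outlook for methyl on the aromatic ring

The source may report more compounds than this note shows. Statements on the series, on what has been measured and on what is new or still open speak of the compounds shown alone.

Measured so far in an assay on isolated protein for inhibition of Dihydrofolate reductase (Mus musculus); a lower number here means a less potent compound, a higher number a more potent compound, by a factor of ten per unit of this negative logarithm:
compound 1, `CC1(C)N=C(N)N=C(N)N1c1ccc(OCCCNC(=O)c2ccc(S(=O)(=O)F)cc2)c(Cl)c1`, 7.34
compound 2, `CC1(C)N=C(N)N=C(N)N1c1ccc(OCCCNC(=O)Nc2ccc(S(=O)(=O)F)cc2)c(Cl)c1`, 7.68
compound 3, `CC1(C)N=C(N)N=C(N)N1c1ccc(OCc2cccc(S(=O)(=O)F)c2)c(Cl)c1`, 7.72

Compound 2 holds the second highest of the three numbers in this assay. Its nearest neighbour is compound 3, a number that sits within the scatter of repeated measurements, so no order between the two can be claimed. Among the compounds with values here, its furthest is compound 1: the change a number 0.34 log units higher from compound 1 to compound 2 (beyond the scatter), which replaces 4-(fluorosulfonyl)phenyl on a carbonyl carbon with (4-(fluorosulfonyl)phenyl)amino, is the only step in the set that lies beyond the scatter.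

Compound 4, `Cc1cc(NC(=O)NCCCOc2ccc(N3C(N)=NC(N)=NC3(C)C)cc2Cl)ccc1S(=O)(=O)F`, is not yet measured. It differs from compound 2 by methyl in place of hydrogen on an aromatic carbon. Within the data shown here, none of the measured compounds carries a substituent on this ring other than the fluorosulfonyl group itself, so no step in the set speaks directly to this change; the one step beyond the scatter concerns the linker, not the ring. With no evidence either way, the expectation is a step of a number 0.02 log units higher from compound 2 to compound 4 (within the scatter), within the scatter. For compound 4 the estimated value in this assay is 7.7, expected to lie between 7.2 and 8.2.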

Compound 4, logarithm of the reciprocal of the active concentration, log(1/C): 8.06
For compound 4 the middle estimate is 0.36 log units below the measured one; the measured number falls inside the stated range.
By their numbers in this assay, from the lowest: compound 1; then compounds 2 and 3 (each within the scatter of the next); then compound 4.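

Methyl in place of hydrogen on an aromatic carbon, ortho to a fluorosulfonyl group, gives a number 0.38 log units higher from compound 2 to compound 4 (beyond the scatter) in this assay, so the ring bearing the fluorosulfonyl group, and not only the linker, now has a step beyond the scatter, and a substituent at this position is compatible with a higher number. Taken with the change from 4-(fluorosulfonyl)phenyl to (4-(fluorosulfonyl)phenyl)amino on the carbonyl carbon, the methyl brings the total to a number 0.72 log units higher from compound 1 to compound 4 (beyond the scatter), the largest step in the set, although the shown compounds cannot establish whether the two changes would add in other settings. No supporting evidence is available to explain the gain from this methyl.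

The compounds shown leave open whether the gain is specific to methyl or would also appear with a larger or different group on the same carbon, such as ethyl or methoxy. They also leave open whether methyl would give a similar step on the ring of compound 1 or compound 3, where the linker differs from that of compound 2.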